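Phenyl for methyl on the thioamide aryl group

This account rests on a few compounds, and the source may have more. Where it says the series, first, only, none or still open, it means among the compounds named here.

Values in a functional assay on MDA-MB-231 cells (Homo sapiens) for inhibition, read by MTT assay, with a stated time of 72 h (on this read-out lower numbers stand for stronger inhibition and higher numbers for weaker inhibition), for the series:

- Compound 1 `COC(=O)c1ccc(-c2nnn(CCCOS(=O)(=O)c3ccc(C)cc3)n2)cc1` gives > 100000 nM as a limit
- Compound 2 `COC(=O)c1ccc(-c2cn(CCCC(=S)Nc3ccc(C)cc3)nn2)cc1` gives > 100000 nM as a limit
- Compound 3 `Cc1ccc(NC(=S)CCCn2cc(-c3ccc(C(F)(F)F)cc3)nn2)cc1` gives 83200 nM as a number
- Compound 4 `COC(=O)c1ccc(-c2cn(CCCC(=S)Nc3ccc(-c4ccccc4)cc3)nn2)cc1` has no value yet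

In this assay compound 2 stands at > 100000 nM as a limit and not as a number. Its place is therefore known only through the limit of > 100000 nM in this assay, at which 2 of the 3 values shown sit, and no exact starting value exists.

The change to compound 4 is phenyl in place of methyl on an aromatic carbon (phenyl in place of methyl on an aromatic carbon, para to a large group). For the measured compounds named here, the only measured step is an at least 1.2-fold lower number from compound 2 to compound 3 (0.07 log units; that floor lies within the scatter) and it concerns a different group, so no measured step gives a size for this replacement of methyl.

Compound 3 reads 83200 nM and so shows that a measured number can be reached in this series. On that basis only a small move toward a lower number is expected, and another limit reading remains quite possible. The expected step is an at least 1.6-fold lower number from compound 2 to compound 4 (0.22 log units; that floor lies within the scatter) in this series. Compound 4 is estimated at 60000 nM in this assay with expected bounds of 15000 nM and 100000 nM for the coming measurement.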

Compound 4, half-maximal inhibitory concentration: > 100000 nM
Compound 4: a limit, no number; the forecaster's own chance of this, stated with the estimate: 50%; at least 1.6-fold (0.22 log units) between middle value and limit.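

In this assay compound 4 gives > 100000 nM, a limit and not a number. Compound 2 also stands at a limit, so no step can be read between compound 2 and compound 4: the limit of > 100000 nM in this assay, at which 3 of the 4 values shown sit.

As far as these compounds go, what phenyl in place of methyl on this aromatic carbon does to the read-out, in direction or in size, stays open.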